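A few compounds are considered here, and "the series" means these few. Any claim that something is new, unique, unknown or untested is made for them only; others in the source may bear on it.

Measured in a functional assay on the whole organism with Rattus norvegicus as the target, at a dose of 100 mg/kg; on this read-out lower numbers stand for less inhibition and higher numbers for more inhibition at the one dose given (going by the name of the read-out):
compound 1 `C/N=C(/NC#N)NCCCCn1nc(N2CCCC2)ccc1=O` gives -1%
compound 2 `C/N=C(/NC#N)NCCCCn1nc(-c2ccc(C)cc2)ccc1=O` gives 45.7%
compound 3 `C/N=C(/NC#N)NCCCCn1nc(Nc2ccccc2)ccc1=O` gives 24.4%

Compound 3 stands second highest of the three numbers; both steps to its neighbours, a number 21.3 percentage points lower from compound 2 to compound 3 (beyond the scatter) and a number 25.4 percentage points higher from compound 1 to compound 3 (beyond the scatter), lie beyond the scatter.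

Compound 4 `C/N=C(/NC#N)NCCCCn1nc(N2CCN(C)CC2)ccc1=O` differs from compound 3 in one place: 4-methylpiperazin-1-yl in place of anilino on an aromatic carbon. Going by the values given here, the steps that bear on it start from compound 1, whose pyrrolidin-1-yl is likewise a non-aromatic ring joined through nitrogen: a number 25.4 percentage points higher from compound 1 to compound 3 (beyond the scatter) and a number 46.7 percentage points higher from compound 1 to compound 2 (beyond the scatter). Both aromatic groups sit well above that ring. Compound 4 returns to a non-aromatic nitrogen-linked ring, so a fall beyond the scatter is expected. Compound 4 is estimated at 5% (range -10% to 25%), a step of a number 19.4 percentage points lower from compound 3 to compound 4 (beyond the scatter), because compound 1 gives -1%.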

Compound 4, a percentage reported as inhibition, in the whole organism at one dose (the size of the read-out at that dose, not a potency): 7.9%
Compound 4: middle estimate off by 2.9 percentage points, on the low side; low and high end bracket the measured number.
By their numbers in this assay, from the lowest: compounds 1 and 4 (each within the scatter of the next); then compound 3; then compound 2.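

In this assay the second non-aromatic ring joined through nitrogen is not separated from pyrrolidin-1-yl, with a number 8.9 percentage points higher from compound 1 to compound 4 (within the scatter) as the step between them. Both aromatic groups stand clear of 4-methylpiperazin-1-yl, with a number 16.5 percentage points lower from compound 3 to compound 4 (beyond the scatter) and a number 37.8 percentage points lower from compound 2 to compound 4 (beyond the scatter) as the steps. On this aromatic carbon, the split between aromatic and non-aromatic groups now holds across all four compounds, with none going against it. Open, as far as these compounds go, is whether morpholin-4-yl or benzyl at this position would follow the aromatic or the non-aromatic groups. Nothing available here says why the groups divide this way.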